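The source may hold more compounds than are shown below. What is called first, only, known or untested is meant among the compounds shown, and "the series" means these compounds.

Compound 1 `CCCCCCCCc1ccc(OCC(=O)Cn2nnc(C(=O)O)n2)cc1` gives 52%. Compound 2 `CCCCCCCCc1ccc(OCC(=O)Cn2nnc(C(=O)OC)n2)cc1` reaches only the limit of the assay at < 5%. Compound 3 `CCCCCCCCc1ccc(OCC(=O)Cn2nnnc2SC)cc1` gives 21%.

In an ADME assay on S9 fraction from liver (Rattus norvegicus) for metabolic stability, read by LC-MS, using NADPH, with a stated time of 30 min (on this read-out higher numbers stand for a more stable compound and lower numbers for a less stable compound), compound 3 stands lowest of the two numbers shown; the nearest number is that of compound 1, and the step of a number 31 percentage points lower from compound 1 to compound 3 (beyond the scatter) lies beyond the scatter. Against the limit seen for compound 2 (the limit of < 5% in this assay, at which 1 of the 3 values shown sits), the step of a number at least 16 percentage points higher from compound 2 to compound 3 (beyond the scatter) runs upward.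

Compound 4 `CCCCCCCCc1ccc(OCC(=O)Cn2nnnc2Cc2ccccc2)cc1` differs from compound 3 in one place: benzyl in place of methylsulfanyl on an aromatic carbon. The measured steps that bear on this position are those onto the five-membered ring, a number 31 percentage points lower from compound 1 to compound 3 (beyond the scatter) and a number at least 16 percentage points higher from compound 2 to compound 3 (beyond the scatter), both large and in opposite directions, so changes at this ring have moved the read-out strongly. For the measured compounds named here, no measured step swaps a methylsulfanyl for a benzyl, so the direction is uncertain; compound 3 already sits low, leaving more room upward than downward. Compound 4 is expected to give 15%, within 4% to 40%, so that the expected step of a number 6 percentage points lower from compound 3 to compound 4 (within the scatter) is modest.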

Compound 4, percent of the compound remaining: 26%
The estimate for compound 4 lay 11 percentage points below the measured number; low and high end bracket the measured number.
By their numbers in this assay, from the lowest: compounds 3 and 4 (each within the scatter of the next); then compound 1. At a limit, below all of these: compound 2.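

In this assay, the swap of methylsulfanyl for benzyl on this aromatic carbon reads as a number 5 percentage points higher from compound 3 to compound 4 (within the scatter), so the two compounds cannot be told apart. The earlier compounds shown here showed only large steps on changing the whole tetrazolyl group, whereas here a far larger group carrying a six-membered aromatic ring enters, the sulfur leaves, and the read-out stays within the scatter. Nothing shown explains why the two groups read alike.

The compounds shown leave open whether this position would stay as undemanding with an amine, a carboxylic acid or a longer chain on the same carbon. They also leave open whether a substituted benzyl group would read any differently from the plain benzyl of compound 4.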